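Swapping 6-oxopiperidin-2-yl for pyrimidin-4-yl on a carbonyl carbon

The compounds below may be only part of what the source reports. "The series", "measured", "known", "first", "only" and "open" are said of these compounds alone.

Measured in a physicochemical assay for solubility, measured as kinetic solubility, with a stated time of 1 h, at pH 7.4; a lower number here means a less soluble compound, a higher number a more soluble compound:
- compound 1 `O=C(Nc1nc(-c2ccc(Cl)c(Cl)c2)cs1)c1cncs1` gives 2000 nM
- compound 2 `N#CCC(=O)Nc1nc(-c2ccc(Cl)c(Cl)c2)ns1` gives 370000 nM
- compound 3 `O=C1CCCC(C(=O)NC2=NN(c3ccc(Cl)c(Cl)c3)CC2)N1` gives 416000 nM

Compound 3 (416000 nM) stands level with compound 2 (370000 nM) within the scatter of repeat measurements, and both lie far above compound 1 (2000 nM).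

The next compound, compound 4 `O=C(NC1=NN(c2ccc(Cl)c(Cl)c2)CC1)c1ccncn1`, has pyrimidin-4-yl in place of 6-oxopiperidin-2-yl on a carbonyl carbon and is otherwise the same as compound 3.

Going by the values given here, no two measured compounds differ in one place only, so this change has no direct precedent here. Among the compounds with values here, the expectation of a clear drop in this assay rests on compound 1 (2000 nM), the only measured compound that also carries an aromatic ring on that carbonyl carbon, although its core differs. The estimated change is a 14-fold lower number from compound 3 to compound 4 (1.14 log units; beyond the scatter) and would lie beyond the scatter. For compound 4 the estimated value is 30000 nM (expected range 6000 nM to 150000 nM).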

Compound 4, solubility: 13000 nM
Estimate against measurement, compound 4: 2.3-fold (0.36 log units) above, and the stated range covers the measured number.
By their numbers in this assay, from the lowest: compound 1; then compound 4; then compounds 2 and 3 (each within the scatter of the next).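

Replacing 6-oxopiperidin-2-yl with pyrimidin-4-yl on a carbonyl carbon gives a direct reading in this assay of a 32-fold lower number from compound 3 to compound 4 (1.51 log units; beyond the scatter) for two compounds that differ in one place only. At this position, then, the read-out depends strongly on the group attached: a non-aromatic ring with a hydrogen-bond donor gives way to an aromatic ring with none, and the number moves well beyond the scatter. No measurement here accounts for the size of this step.

From the compounds shown here alone, it remains open whether the loss of the ring's hydrogen-bond donor or the arrival of the aromatic ring matters more, and a tetrahydropyranyl group or an amine on the pyrimidine would help separate the two. Going by these compounds, whether the same swap behaves alike on the cores of compound 1 and compound 2 also remains open.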